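Oxiran-2-yl for 3-Bromopropyl: an Expected Growth Inhibition

The source may hold more compounds than are shown below. What is called first, only, known or untested is meant among the compounds shown, and "the series" means these compounds.

Measured in a functional assay on HUVEC cells (Homo sapiens) for inhibition, read by MTT assay, with a stated time of 24 h, tested at 10 uM; on this read-out higher numbers stand for more inhibition of growth at the one concentration tested and lower numbers for less inhibition of growth:
compound 1 `COc1cc2ccc(=O)oc2cc1OCC(O)CN1CCN(C)CC1` gives 0.1%
compound 2 `COc1cc2ccc(=O)oc2cc1OCCCCBr` gives 11.2%
compound 3 `CCN(CC)CC(O)COc1cc2oc(=O)ccc2cc1OC` gives 0.5%

Compound 2 stands highest of the three numbers; compound 3 lies nearest and compound 1 furthest, both beyond the scatter. Among the compounds with values here, the only measured step, a number 0.4 percentage points higher from compound 1 to compound 3 (within the scatter), concerns the amine at the far end of the chain and says nothing about the halide end. Within the data shown here, the change to compound 4 `COc1cc2ccc(=O)oc2cc1OCC1CO1` is oxiran-2-yl in place of 3-bromopropyl on a saturated chain carbon bound to an oxygen on an aromatic ring, and no measured pair bears on it. With nothing to argue for a shift, the step of a number 0.8 percentage points higher from compound 2 to compound 4 (within the scatter) is expected to stay within the scatter, and compound 4 is estimated at 12%, in a range from 0% to 30%.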

Compound 4, percent growth inhibition at one concentration: 62.2%
The estimate for compound 4 lay 50.2 percentage points below the measured number; measured number outside the range, above it.
By their numbers in this assay, from the lowest: compounds 1 and 3 (each within the scatter of the next); then compound 2; then compound 4.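

In this assay oxiran-2-yl in place of 3-bromopropyl brings a number 51 percentage points higher from compound 2 to compound 4 (beyond the scatter) and so shows that this end of the chain can move growth inhibition strongly. The only earlier step, a number 0.4 percentage points higher from compound 1 to compound 3 (within the scatter) between two amines, had shown no such movement. Nothing available explains the rise.

The compounds shown cannot separate the gain of the oxiran-2-yl ring from the loss of the bromine. Going by these compounds, whether cyclopropyl in its place, or a longer chain carrying the oxiran-2-yl, would give a similar number remains open.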